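The source may report more compounds than this note shows. Statements on the series, on what has been measured and on what is new or still open speak of the compounds shown alone.

In an in vitro assay on HEK-tsA201 cells for antagonist activity at Neuronal acetylcholine receptor; alpha4/beta2 (Homo sapiens), read by fluorescence and calcium flux (on this read-out higher numbers stand for weaker inhibition and lower numbers for stronger inhibition), compound 3, `CCCOc1ccc(C(=O)Nc2cccc(Cl)n2)cc1`, gives > 100000 nM, which is a limit and not a number. Compound 2, `C=CCOc1ccc(C(=O)Nc2cccc(Cl)n2)cc1`, likewise gives the limit > 100000 nM. Compound 1, `C#CCOc1ccc(C(=O)Nc2cccc(C)n2)cc1`, gives a measured number, 19400 nM. Among the measured compounds shown here, the one measured step that changes a single place, a step that the two limits leave unreadable from compound 2 to compound 3, cannot be read, since both of its compounds sit at the limit of > 100000 nM in this assay, at which 2 of the 3 values shown sit. Compound 1 and compound 3 differ in two places at once, so their two values show only a number for compound 1 and a limit for compound 3.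

Compound 4, `CCCCCNc1cccc(NC(=O)c2ccc(OCCC)cc2)n1`, differs from compound 3 by pentylamino in place of chloro on an aromatic carbon. For the measured compounds named here, no measured step exchanges a chloro for a pentylamino, so none bears directly on this change, and the measured steps give no size to carry over. Where compound 3 stands, only a limit is known, so the starting point itself is not a number. The estimate for compound 4 in this assay is 30000 nM, within an expected range from 5000 nM to 100000 nM. The expected step, an at least 3.3-fold lower number from compound 3 to compound 4 (0.52 log units; beyond the scatter), comes with a real chance that compound 4 again shows only a limit.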

Compound 4, half-maximal inhibitory concentration: > 100000 nM
Compound 4: only a limit was reported (the forecaster's own chance of this, stated with the estimate: 50%); middle value at least 3.3-fold (0.52 log units) away from the limit.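

Compound 3 and compound 4 each give a limit and not a number, so no new step can be read between them, because both sit at the same limit: the limit of > 100000 nM in this assay, at which 3 of the 4 values shown sit.

The compounds shown leave open whether pentylamino in place of chloro changes the inhibition at all, and if so, by how much.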